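Alkoxy variation on the shared core of compound 3

A few compounds are considered here, and "the series" means these few. Any claim that something is new, unique, unknown or untested is made for them only; others in the source may bear on it.

Compound 3 `CC(Oc1ccccc1OC1CC1)C1=NCCN1` gives 12900 nM in a functional assay on CHO cells for agonist activity at Alpha-2B adrenergic receptor (Homo sapiens) (on this read-out higher numbers stand for an effect only at larger amounts of compound and lower numbers for an effect already at smaller amounts), the highest of the three numbers recorded. Compound 1 `C=C(C)c1ccccc1OC(C)C1=NCCN1` gives 1580 nM and compound 2 `CC(C)Oc1ccccc1OC(C)C1=NCCN1` gives 1740 nM; between them, a 1.1-fold higher number from compound 1 to compound 2 (0.04 log units; within the scatter). The change to compound 4 `C=COc1ccccc1OC(C)C1=NCCN1` is vinyl in place of cyclopropyl on an oxygen on an aromatic ring. For the measured compounds named here, no measured step matches this exactly. Going by the values given here, the steps that bear on it are a 7.4-fold higher number from compound 2 to compound 3 (0.87 log units; beyond the scatter), which alters the group on the same oxygen, and an 8.2-fold higher number from compound 1 to compound 3 (0.91 log units; beyond the scatter), which installs the cyclopropyloxy group. Both place compound 3 well beyond the other two, so leaving the cyclopropyl is expected to bring a lower number for compound 4, of uncertain size. The step expected from compound 3 to compound 4 is a 3.2-fold lower number from compound 3 to compound 4 (0.51 log units; beyond the scatter). Compound 4 is estimated at 4000 nM, within 1500 nM to 11000 nM.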

Compound 4, half-maximal effective concentration: 3160 nM
For compound 4 the middle estimate is 1.3-fold (0.10 log units) above the measured one, within the range that was stated.
By their numbers in this assay, from the lowest: compounds 1, 2 and 4 (each within the scatter of the next); then compound 3.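

In this assay, vinyl on the oxygen on the aromatic ring gives a clear step away from cyclopropyl (a 4.1-fold lower number from compound 3 to compound 4 (0.61 log units; beyond the scatter)), so among these compounds the high number of compound 3 goes with the cyclopropyl and not with every small group at this place. Vinyl does not separate from isopropyl (a 1.8-fold higher number from compound 2 to compound 4 (0.26 log units; within the scatter)) or from 1-methylethenyl on the aromatic carbon (a 2.0-fold higher number from compound 1 to compound 4 (0.30 log units; within the scatter)). Nothing at hand gives a reason for the cyclopropyl step.

Open, on these data alone, is whether a cyclobutyl ring or a longer chain on the oxygen would stand with compound 3 or with compound 1, compound 2 and compound 4. As far as these compounds go, an amine at this place is equally open.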